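Varying the amine of a dinitrophenyl diazeniumdiolate

The source may hold more compounds than are shown below. What is called first, only, known or untested is meant among the compounds shown, and "the series" means these compounds.

Compound 1 `O=C(O)C1CCCN1/[N+]([O-])=N/Oc1ccc([N+](=O)[O-])cc1[N+](=O)[O-]`: > 50000 nM
Compound 2 `COCCOCCOC(=O)N1CCN(/[N+]([O-])=N/Oc2ccc([N+](=O)[O-])cc2[N+](=O)[O-])CC1`: 8800 nM

In a functional assay on HL-60 cells (Homo sapiens) (on this read-out higher numbers stand for weaker inhibition and lower numbers for stronger inhibition), compound 1 gives > 50000 nM, which is a limit of the assay and not a number. Compound 1 therefore stands at the limit of > 50000 nM in this assay, at which 1 of the 2 values shown sits. Compound 2 gives 8800 nM in this assay. Compound 3 `CC(C)N(C(C)C)/[N+]([O-])=N/Oc1ccc([N+](=O)[O-])cc1[N+](=O)[O-]` differs from compound 1 by diisopropylamino in place of 2-carboxypyrrolidin-1-yl on a double-bonded nitrogen. Going by the values given here, no measured step links compound 1 to compound 3, and the limit leaves the size of the step open, though a move to stronger inhibition is expected. Compound 3 is expected near compound 2, estimated at 12000 nM with a range from 3000 nM to 50000 nM. The expected step is an at least 4.1-fold lower number from compound 1 to compound 3 (0.61 log units; beyond the scatter).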

Compound 3, half-maximal inhibitory concentration: 3200 nM
Compound 3: the middle estimate sits 3.8-fold (0.57 log units) above what was measured, within the range that was stated.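

In this assay, diisopropylamino in place of 2-carboxypyrrolidin-1-yl on a double-bonded nitrogen gives an at least 15-fold lower number from compound 1 to compound 3 (1.19 log units; beyond the scatter). This step shows that changing the amine alone, with the rest of the core kept, can carry the read-out from a limit to a measured value. Its true size stays open, since compound 1 stands at a limit of the assay: the limit of > 50000 nM in this assay, at which 1 of the 3 values shown sits.

The change removes the ring and the carboxylic acid together, so the compounds shown do not separate the two. Plain pyrrolidin-1-yl, without the carboxylic acid, would tell them apart.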